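A few compounds are considered here, and "the series" means these few. Any claim that something is new, unique, unknown or untested is made for them only; others in the source may bear on it.

Measured so far in a functional assay on TK-10 cells (Homo sapiens) for cytotoxicity, read by sulforhodamine B assay, with a stated time of 48 h; a lower number here means a stronger inhibitor of growth, a higher number a weaker inhibitor of growth:

compound 1 `ClCc1ccccc1Cn1cnc2c(Cl)nc(Cl)nc21`: 2880 nM
compound 2 `ClCc1cccc(Cn2cnc3c(Cl)nc(Cl)nc32)c1`: 3980 nM
compound 3 `Nc1nc(Cl)c2ncn(Cc3ccccc3CCl)c2n1`: 36300 nM

Compound 1 and compound 2 share the same atoms joined differently; the difference between the two cores is not broken down here. Their values lie within the scatter of each other, so no order is read between them. Compound 3 comes from compound 1 by amino in place of chloro on an aromatic carbon, and this step, a 13-fold higher number from compound 1 to compound 3 (1.10 log units; beyond the scatter), is the one large move in the set. Against compound 2, compound 3 sits further away by a margin beyond the scatter.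

Compound 4 `Nc1nc(Cl)c2ncn(Cc3cccc(CCl)c3)c2n1` is not yet measured. It arises from compound 2 by amino in place of chloro on an aromatic carbon, the same change as from compound 1 to compound 3, at the same kind of place, described in identical terms. For the measured compounds named here, with only the single pair of compound 1 and compound 3 as precedent, the step is expected to repeat at a similar size: the expected step is a 13-fold higher number from compound 2 to compound 4 (1.10 log units; beyond the scatter), because the earlier pair gave a 13-fold higher number from compound 1 to compound 3 (1.10 log units; beyond the scatter). For compound 4 in this assay the estimate is 50000 nM, likely between 20000 nM and 130000 nM.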

Compound 4, concentration for total growth inhibition: 7080 nM
Compound 4: middle estimate off by 7.1-fold (0.85 log units), on the high side; measured number below the stated range.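

In this assay, amino in place of chloro on an aromatic carbon does not move the number by one size across the two cores: the same change on two cores in this assay, a 13-fold higher number (1.10 log units; beyond the scatter) from compound 1 to compound 3 and a 1.8-fold higher number (0.25 log units; within the scatter) from compound 2 to compound 4, 7.1-fold (0.85 log units) apart, beyond the scatter of two such steps. The step on the second core is a 1.8-fold higher number from compound 2 to compound 4 (0.25 log units; within the scatter), so no order is read between these two compounds, and the large move on the core of compound 1 cannot be carried over as a fixed increment. Two pairs do not show what separates the cores, nor which size would be typical on a further core in this series.

Still open, from the compounds shown here alone, is whether a methylamino group, a methoxy group or a hydrogen in place of that chloro would also give different step sizes on the two cores. Also open, going by these compounds, is whether the difference between the cores persists when the chloromethyl group is replaced by a methyl or hydroxymethyl group.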